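The source may hold more compounds than are shown below. What is called first, only, known or untested is meant among the compounds shown, and "the series" means these compounds.

Notes on the series. Compound 1 `COc1cc(C)cc(-c2c(-c3ccnc(-c4ccc(C(C)=O)cc4)c3)cnn2CC#N)c1` carries an acetyl group on the outer phenyl ring. In a functional assay on UO-31 cells (Homo sapiens) for inhibition, read by sulforhodamine B assay, with a stated time of 48 h (on this read-out lower numbers stand for stronger inhibition of growth and higher numbers for weaker inhibition of growth), compound 1 gives > 100000 nM; this is a limit of the assay, not a number, and compound 1 is the one of the three measured compounds that sits at it (the limit of > 100000 nM in this assay, at which 1 of the 3 values shown sits). The two further measured members are compound 2 `Cc1cc(O)cc(-c2nn(CC#N)cc2-c2ccnc(-c3ccc(Oc4ccccc4)cc3)c2)c1` and compound 3 `COc1cc(C)cc(-c2nn(CC#N)cc2-c2ccnc(-c3ccc(N(C)C)cc3)c2)c1`. In this assay compound 2 gives 6540 nM, while compound 3 gives 98700 nM. Within the data shown here, no pair of measured compounds differs in a single place, so no measured step exists.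

The compound to be measured next is compound 4 `COc1cc(C)cc(-c2c(-c3ccnc(-c4ccc(N(C)C)cc4)c3)cnn2CC#N)c1`. From compound 1 it differs in one place: dimethylamino in place of acetyl on an aromatic carbon. Compound 3 also bears a dimethylamino group and gives 98700 nM; the expectation is therefore that compound 4 stays weak, with the step of a number no higher from compound 1 to compound 4 (the limit leaves the size open) not reaching beyond the scatter. Compound 4 is estimated at 100000 nM, within 30000 nM to 300000 nM.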

Compound 4, concentration for total growth inhibition: > 100000 nM
Compound 4 was reported as a limit; the forecaster's own chance of this, stated with the estimate: 50%; the middle value lies on the limit itself.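

Compound 1 and compound 4 are both reported as limits of the assay, so no step can be read between them: the limit of > 100000 nM in this assay, at which 2 of the 4 values shown sit.

The compounds shown leave open whether dimethylamino in place of acetyl changes growth inhibition at all in this assay on this shared core.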